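Phenyl for Benzyl on the Urea Nitrogen: Compound 4

A few compounds are considered here, and "the series" means these few. Any claim that something is new, unique, unknown or untested is made for them only; others in the source may bear on it.

Measured compounds:
Compound 1, `CCCCCCCCCNC(=O)N(Cc1cc(OC)ccc1OC)n1cnnc1`, in a functional assay on B16-F10 cells (Mus musculus) for cytotoxicity, read by MTT assay, with a stated time of 48 h; on this read-out higher numbers stand for weaker inhibition and lower numbers for stronger inhibition: 29400 nM
Compound 2, `COc1cc(CN(C(=O)Nc2ccc(C)cc2)n2cnnc2)cc(OC)c1OC`, in this assay: 46800 nM
Compound 3, `O=C(NCc1ccccc1)N(Cc1ccccn1)n1cnnc1`, in this assay: 31000 nM

All three measured compounds share a urea bearing the same five-membered heteroaryl substituent on one nitrogen, and all three give weak numbers in this assay. Compound 3 holds the second highest of the three numbers; its nearest neighbour is compound 1, whose number sits within the scatter of it, and its furthest neighbour is compound 2, whose number also stays within the scatter. On these data no ordering among the three can be claimed.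

Compound 4, `O=C(Nc1ccccc1)N(Cc1ccccn1)n1cnnc1`, is the one open question. It differs from compound 3 in one place: phenyl in place of benzyl on an amide-type nitrogen. Within the data shown here, no comparable step between two measured compounds exists in this set, so the expectation rests only on the narrow spread of the three measured numbers. Compound 2 already carries an aromatic ring directly on that amide-type nitrogen and gives 46800 nM, which is no better than the others. Compound 4 is therefore expected to stay in the same weak range, with the step of a 1.3-fold higher number from compound 3 to compound 4 (0.11 log units; within the scatter) estimated as none beyond the scatter. The estimate for compound 4 in this assay is 40000 nM, within a range of 15000 nM to 110000 nM.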

Compound 4, half-maximal inhibitory concentration: 23700 nM
Estimate against measurement, compound 4: 1.7-fold (0.23 log units) above; low and high end bracket the measured number.
By their numbers in this assay, from the lowest: compounds 4, 1, 3 and 2 (each within the scatter of the next).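

In this assay, among these compounds, the pair gives the first reading of a single change, phenyl in place of benzyl on an amide-type nitrogen whose other neighbour is the carbonyl carbon, and the step is a 1.3-fold lower number from compound 3 to compound 4 (0.12 log units; within the scatter). The earlier compounds shown here differed from one another in more than one place and could not isolate this position; here benzyl's 7 heavy atoms give way to phenyl's 6, the six-membered aromatic ring of carbon stays, and compound 3 and compound 4 cannot be told apart. No measurement bearing on why these two numbers stay together accompanies the result.

As far as these compounds go, whether a carboxylic acid or an amine on that phenyl ring would give a number beyond the scatter of compound 4 remains open, as does the effect of a longer chain on the same nitrogen. Also open is whether phenyl in place of benzyl would read the same way with other groups elsewhere on the shared core, as this is the only such pair shown.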